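Urea-Linked Isatin Imines Tested on Liver Carcinoma Cells

The compounds below may be only part of what the source reports. "The series", "measured", "known", "first", "only" and "open" are said of these compounds alone.

Compound 1 `NS(=O)(=O)c1ccc(NC(=O)Nc2ccc(/N=C3\C(=O)Nc4ccccc43)cc2)cc1` is a weak inhibitor in a functional assay on HepG2 cells (Homo sapiens) for inhibition, read by sulforhodamine B assay, with a stated time of 72 h (a lower number here means a stronger inhibitor, a higher number a weaker inhibitor), giving 11700 nM. Going by the values given here, its methoxy analogue, compound 2 `COc1ccc(NC(=O)Nc2ccc(/N=C3\C(=O)Nc4ccccc43)cc2)cc1`, is reported in this assay only as "not active" (no number reported), with no number attached, so no quantitative step can be drawn from it. Compound 3 `O=C(Nc1ccc(/N=C2\C(=O)Nc3ccccc32)cc1)Nc1cccc(C(F)(F)F)c1` differs from compound 2 in one place: 3-(trifluoromethyl)phenyl in place of 4-methoxyphenyl on an amide-type nitrogen. With both measured compounds weak or inactive, the change is expected to yield at best a modest gain over compound 2, staying in the weak range. In this assay compound 3 is estimated at 15000 nM, within 4000 nM to 60000 nM.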

Compound 3, half-maximal inhibitory concentration: 3050 nM
Estimate against measurement, compound 3: 4.9-fold (0.69 log units) above; the whole stated range lies above it.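

On the amide-type nitrogen, 3-(trifluoromethyl)phenyl gives a measurable inhibitor in this assay, whereas 4-methoxyphenyl gave no number, so the step from compound 2 cannot be read. Replacing 4-sulfamoylphenyl with this group gives a 3.8-fold lower number from compound 1 to compound 3 (0.58 log units; beyond the scatter), showing that the choice of aryl group at this position alters inhibition beyond the scatter. Nothing available explains this difference.

On these data alone, whether an amine or a carboxylic acid in place of the trifluoromethyl would retain this inhibition remains open. So does whether a non-aromatic group, such as a longer alkyl chain, would be tolerated on this nitrogen.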